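Moving a methoxy group around a phenyl ring

The compounds below may be only part of what the source reports. "The series", "measured", "known", "first", "only" and "open" are said of these compounds alone.

Compound 1: `C[C@H]1CC[C@@H]2[C@@H](OC(=O)[C@]23CC(c2ccccc2Br)=NO3)[C@]2(C)C(=O)C=C[C@@]12O` — 2.22
Compound 2: `C[C@H]1CC[C@@H]2[C@@H](OC(=O)[C@]23CC(c2ccccc2[N+](=O)[O-])=NO3)[C@]2(C)C(=O)C=C[C@@]12O` — 1.37
Compound 3: `COc1ccc(C2C[C@@]3(ON2c2ccccc2)C(=O)O[C@@H]2[C@H]3CC[C@H](C)[C@]3(O)C=CC(=O)[C@@]23C)cc1` — 3.25

In a physicochemical assay for lipophilicity (a higher number here means a more lipophilic compound, a lower number a more polar compound), compound 3 gives the highest of the three numbers. Compound 1 is nearest to it, lying a number beyond the scatter below it, and compound 2 is furthest, also beyond the scatter below it. The only measured step among these compounds, a number 0.85 log units lower from compound 1 to compound 2 (beyond the scatter), concerns an aromatic substituent exchange and does not involve a methoxyphenyl group at all.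

Compound 4 is `COc1cccc(C2C[C@@]3(ON2c2ccccc2)C(=O)O[C@@H]2[C@H]3CC[C@H](C)[C@]3(O)C=CC(=O)[C@@]23C)c1`. It differs from compound 3 in one place: 3-methoxyphenyl in place of 4-methoxyphenyl on a saturated ring carbon. The two compounds have the same atoms, joined differently, and the group that leaves and the group that enters each carry one hydrogen-bond acceptor and no donor.

Within the data shown here, no measured step in this set mirrors such a rearrangement. The change neither adds nor removes atoms, so in this assay the expected step of no change at the digits printed from compound 3 to compound 4 (within the scatter) is none beyond the scatter. For compound 4 the estimate is 3.25, with a range from 2.85 to 3.65.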

Compound 4, partition coefficient: 3.25
For compound 4 middle estimate and measured number coincide at the digits printed, within the range that was stated.
By their numbers in this assay, from the lowest: compound 2; then compound 1; then compounds 3 and 4 (each within the scatter of the next).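

In this assay, 3-methoxyphenyl in place of 4-methoxyphenyl on this saturated ring carbon gives no change at the digits printed from compound 3 to compound 4 (within the scatter), so for this pair the place of the methoxy group on the phenyl ring does not separate the two numbers. Among these compounds, the only earlier step, a number 0.85 log units lower from compound 1 to compound 2 (beyond the scatter), exchanged one substituent for another on an aromatic carbon and could not show what a rearrangement of the same atoms does at this position. Nothing measured here speaks to why the two numbers agree.

The compounds shown leave open whether this agreement extends beyond this one pair of methoxyphenyl groups. They also leave open how the number would respond on this saturated ring carbon if the phenyl ring carried an amine or a carboxylic acid in place of the methoxy group.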